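From furan-2-yl to furan-3-yl on a sulfonyl sulfur

A few compounds are considered here, and "the series" means these few. Any claim that something is new, unique, unknown or untested is made for them only; others in the source may bear on it.

Measured in an ADME assay on the whole organism (plasma, Rattus norvegicus, strain Sprague-Dawley) for pharmacokinetics, read by LC-MS, using cassette dosing, at a dose of 0.2 mg/kg by the intravenous route (a higher number here means more compound in the circulation at the dose given, a lower number less compound in the circulation), so far:
Compound 1 `CNCc1cc(-c2cccnc2F)n(S(=O)(=O)c2cccnc2)c1` gives 35 ng.h/mL
Compound 2 `CNCc1cn(S(=O)(=O)c2cccs2)c(-c2cccnc2F)c1F` gives 42 ng.h/mL
Compound 3 `CNCc1cn(S(=O)(=O)c2ccco2)c(-c2cccnc2F)c1F` gives 26 ng.h/mL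

Compound 3 stands at 26 ng.h/mL in this small set. The three values lie within the usual scatter of one another, so these numbers do not set compound 3 apart from compound 1 or compound 2. Compound 4 `CNCc1cn(S(=O)(=O)c2ccoc2)c(-c2cccnc2F)c1F` has the same atoms as compound 3, joined differently. The whole change is furan-3-yl in place of furan-2-yl on a sulfonyl sulfur with furan-3-yl in place of furan-2-yl on a sulfonyl sulfur.

Going by the values given here, no measured step makes this exact change. The closest evidence is a 1.6-fold lower number from compound 2 to compound 3 (0.21 log units; within the scatter) on the same sulfonyl sulfur, and that exchange of thiophen-2-yl for furan-2-yl stayed within the scatter. Compound 1 differs from compound 3 in more than one place, so it offers no clean comparison. In this assay the estimated step is a 1.1-fold higher number from compound 3 to compound 4 (0.03 log units; within the scatter) and it is expected to stay within the scatter, with no firm direction. Compound 4 is expected at 28 ng.h/mL with an estimated range from 14 ng.h/mL to 55 ng.h/mL in this measurement.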

Compound 4, area under the concentration-time curve: 41 ng.h/mL
Compound 4: the middle estimate sits 1.5-fold (0.17 log units) below what was measured; the range from low to high includes it.
By their numbers in this assay, from the lowest: compounds 3, 1, 4 and 2 (each within the scatter of the next).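

In this assay there is a 1.6-fold higher number from compound 3 to compound 4 (0.20 log units; within the scatter), so furan-3-yl in place of furan-2-yl on a sulfonyl sulfur gives a step that stays within the scatter, and the two furans are not told apart in this measurement. The comparison with the sulfur-containing ring reads the same way, with a 1.0-fold lower number from compound 2 to compound 4 (0.01 log units; within the scatter), and together with the earlier step between thiophen-2-yl and furan-2-yl this places all three five-membered aromatic rings at this position within the scatter of one another. Nothing available here bears on why these numbers lie where they do.

What remains open is whether any group on this sulfonyl sulfur can carry the area under the curve beyond the scatter, since each step shown among compound 2, compound 3 and compound 4 stays inside it. A phenyl ring, or a furan bearing a methyl group or a carboxylic acid, would put that question to a larger change than the exchanges seen so far.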